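Swapping a Benzyl for a Pyrrolidinylethyl Chain

A few compounds are considered here, and "the series" means these few. Any claim that something is new, unique, unknown or untested is made for them only; others in the source may bear on it.

Compound 1 `O=C(Nc1ccc(C(=O)N2CCCN(Cc3ccccc3)c3sccc32)cc1)c1ccccc1-c1ccccc1`: 70 nM
Compound 2 `CN(C)C1CCN(C(=O)CCCOc2cc(C(=O)N3CCCCc4sccc43)ccc2NC(=O)c2ccccc2-c2ccccc2)CC1`: 3 nM

Of the compounds shown here, two have been measured in an assay on adrenal medulla for inhibition of Vasopressin V2 receptor (Rattus norvegicus), read by radioligand binding; on this read-out higher numbers stand for weaker inhibition and lower numbers for stronger inhibition. Compound 1 gives 70 nM, which is the higher of the two numbers; its nearest neighbour, compound 2, gives 3 nM, a gap described as beyond the usual scatter. Among the compounds with values here, no single-point step between measured compounds exists, so the two values can only be read side by side.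

Compound 3 `O=C(Nc1ccc(C(=O)N2CCCN(CCN3CCCC3)c3sccc32)cc1)c1ccccc1-c1ccccc1` differs from compound 1 in one place: (pyrrolidin-1-yl)methyl in place of phenyl on a saturated chain carbon bound to a nitrogen on an aromatic ring in a ring. Cut one bond further out, the change reads benzyl to 2-(pyrrolidin-1-yl)ethyl.

Within the data shown here, with no measured step of this kind available, the expectation rests on the two numbers alone. A step toward lower numbers, of moderate size, is expected from compound 1 to compound 3 a 3.5-fold lower number from compound 1 to compound 3 (0.54 log units; beyond the scatter), because compound 2, which also carries an amine in its side chain, gives 3 nM. Compound 3 is therefore estimated at 20 nM, with a range from 4 nM to 100 nM.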

Compound 3, half-maximal inhibitory concentration: 10 nM
The estimate for compound 3 lay 2.0-fold (0.30 log units) above the measured number; the range from low to high includes it.
By their numbers in this assay, from the lowest: compound 2; then compound 3; then compound 1.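

In this assay, within the data shown here, the exchange of benzyl for 2-(pyrrolidin-1-yl)ethyl gives a 7.0-fold lower number from compound 1 to compound 3 (0.85 log units; beyond the scatter), and this is the first single-change reading at this position, a saturated chain carbon bound to a nitrogen on an aromatic ring in a ring. It shows that the phenyl group is not required at this place: with a six-membered aromatic ring of carbon only gone and a five-membered non-aromatic ring with one hetero atom in its stead, the number moves lower, by a margin beyond the usual scatter. No measurement in hand accounts for this step, so the data give its size and direction but no explanation of it.

The compounds shown do not separate the contribution of the pyrrolidine ring from that of the chain that carries it, a question that a 2-(dimethylamino)ethyl group, a 2-(piperidin-1-yl)ethyl group or a plain ethyl group at this place would address. On these data alone, it also remains open how the length of the chain bears on the result, as a 3-(pyrrolidin-1-yl)propyl group would show, and whether a carboxylic acid at the end of the chain would move the number the same way.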